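Nitro for fluoro on the phenoxy ring: lipophilicity notes

The source may hold more compounds than are shown below. What is called first, only, known or untested is meant among the compounds shown, and "the series" means these compounds.

Measured compounds:
compound 1, `O=[N+]([O-])c1ccc(Oc2ccc(/C=N/Nc3nc4ccccc4s3)cc2)cc1`, in a physicochemical assay for lipophilicity, in phosphate buffer, measured as octanol-water partition, with a stated time of 24 h (on this read-out lower numbers stand for lower lipophilicity and higher numbers for higher lipophilicity), gives 5.1
compound 2, `Fc1ccc(Oc2ccc(/C=N/Nc3nc4ccccc4s3)cc2)cc1`, in this assay gives 5
compound 3, `O=C(CSc1nc2ccccc2s1)N/N=C/c1ccc(Oc2ccc(F)cc2)cc1`, in this assay gives 5.5

Compound 1 and compound 2 share one core and differ only by nitro in place of fluoro on an aromatic carbon, a change that gave a number 0.10 log units higher from compound 2 to compound 1 (within the scatter). Compound 3 has a different core from compound 2; the difference between the two cores is not broken down here. Among the three, compound 3 stands highest in this assay, beyond the scatter from both others.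

Compound 4, `O=C(CSc1nc2ccccc2s1)N/N=C/c1ccc(Oc2ccc([N+](=O)[O-])cc2)cc1`, is not yet measured. Against compound 3 it carries the same change as seen between the first pair: nitro in place of fluoro on an aromatic carbon, at the same place. The step of a number 0.10 log units higher from compound 3 to compound 4 (within the scatter) is expected to be small, because the same change gave a number 0.10 log units higher from compound 2 to compound 1 (within the scatter). For compound 4 the value expected in this assay is 5.6, between 5.2 and 6.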

Compound 4, partition coefficient: 5.3
Compound 4: the middle estimate sits 0.30 log units above what was measured; the measured number falls inside the stated range.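

In this assay nitro in place of fluoro gives a number 0.20 log units lower from compound 3 to compound 4 (within the scatter) and, on the other core, a number 0.10 log units higher from compound 2 to compound 1 (within the scatter) so on both cores shown the step stays within the scatter. That is a single pair on each of two cores: it shows the change carrying over in this one read-out, but it sets no rule for further cores and, with both steps inside the scatter, fixes no direction for the change. Nothing available bears on why the steps come out this way.

Open, going by these compounds, is whether an amine or a carboxylic acid in place of fluoro at the same place would also stay within the scatter. Also open, on these data alone, is whether such a group would behave alike on the two cores.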